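Cytotoxicity of a Nitro-Substituted Anilide in a Sulfone Series

A few compounds are considered here, and "the series" means these few. Any claim that something is new, unique, unknown or untested is made for them only; others in the source may bear on it.

Measured compounds:
compound 1, `Cc1cc(C#N)cc(C)c1Oc1ccnc(S(=O)(=O)CC(=O)Nc2ccccc2)n1`: 29300 nM
compound 2, `Cc1cc(C#N)cc(C)c1Oc1ccnc(S(=O)(=O)CC(=O)Nc2ccc(F)cc2)n1`: 26100 nM
compound 3, `Cc1cc(C#N)cc(C)c1Oc1ccnc(S(=O)(=O)CC(=O)Nc2cc(Cl)cc(Cl)c2)n1`: 24000 nM

All three compounds share the same core and differ only in the ring attached to the amide-type nitrogen. They were tested in an ADME assay on MT4 cells (Homo sapiens) for cytotoxicity, read by MTT assay, with a stated time of 4 days; on this read-out lower numbers stand for higher toxicity in this test and higher numbers for lower toxicity in this test. Compound 1 has the highest of the three numbers, but the gaps to the others are small: a 1.1-fold lower number from compound 1 to compound 2 (0.05 log units; within the scatter) and a 1.2-fold lower number from compound 1 to compound 3 (0.09 log units; within the scatter). Compounds 2 and 3 also lie close together, a 1.1-fold lower number from compound 2 to compound 3 (0.04 log units; within the scatter). Within this set, exchanging substituents on that ring has not moved the read-out beyond the usual scatter.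

Compound 4, `Cc1cc(C#N)cc(C)c1Oc1ccnc(S(=O)(=O)CC(=O)Nc2cccc([N+](=O)[O-])c2)n1`, has not yet been measured in this assay. Compared with compound 1 it differs in one place: nitro in place of hydrogen on an aromatic carbon. The steps from compound 1 to compound 2 and from compound 1 to compound 3 bear on this change, since both add groups to the same ring, and both stayed within the scatter. The same is therefore expected here, with no step beyond the scatter in this assay in either direction.

Compound 4 is estimated to give 27000 nM, with a range from 14000 nM to 54000 nM. The expected step, a 1.1-fold lower number from compound 1 to compound 4 (0.04 log units; within the scatter), would stay within the scatter.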

Compound 4, half-maximal cytotoxic concentration: 23600 nM
Compound 4: the middle estimate sits 1.1-fold (0.06 log units) above what was measured, and the stated range covers the measured number.
By their numbers in this assay, from the lowest: compounds 4, 3, 2 and 1 (each within the scatter of the next).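

In this assay, adding a nitro group to the aniline-derived phenyl ring of compound 1, on an aromatic carbon meta to a large group, gives a 1.2-fold lower number from compound 1 to compound 4 (0.09 log units; within the scatter). The earlier compounds shown here carried only fluoro or chloro on this ring, so this shows that a group of three heavy atoms, with nitrogen and oxygen and two hydrogen-bond acceptors, also leaves the read-out within the scatter, and the exchanges between substituted rings agree, with a 1.0-fold lower number from compound 3 to compound 4 (0.01 log units; within the scatter) and a 1.1-fold lower number from compound 2 to compound 4 (0.04 log units; within the scatter). Nothing available explains why the number stays level across these rings.

The compounds shown leave open whether an amine or a carboxylic acid on this ring, or a longer chain in its place, would produce a step beyond the scatter. From the compounds shown here alone, all four compounds also share the same core and the same sulfone-acetamide link, so it remains open whether changing either of those would shift the number in this cell test, which the ring exchanges cannot answer.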